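A few compounds are considered here, and "the series" means these few. Any claim that something is new, unique, unknown or untested is made for them only; others in the source may bear on it.

Compound 1, `COc1ccccc1N1CCN(CCCCCCn2nc(N3CCN(C(=O)c4ccco4)CC3)ccc2=O)CC1`, is the starting point of this comparison. In an assay on cell membranes for binding affinity to Adrenergic receptor alpha-1 (Rattus norvegicus), read by radioligand binding (a higher number here means a weaker inhibitor, a lower number a stronger inhibitor), compound 1 gives 17.8 nM. Compound 2, `O=C(c1ccco1)N1CCN(c2ccc(=O)n(CCCCCCN3CCN(c4ccccc4Cl)CC3)n2)CC1`, carries one change relative to compound 1, namely (chloro in place of methoxy on an aromatic carbon). In this assay compound 2 gives 5.9 nM. The step that this change made is a 3.0-fold lower number from compound 1 to compound 2 (0.48 log units; beyond the scatter).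

Compound 3, `COc1ccccc1N1CCN(CCCCCCCn2nc(N3CCN(C(=O)c4ccco4)CC3)ccc2=O)CC1`, belongs to a second core; the difference between the core of compound 1 and the core of compound 3 is not broken down here. In this assay, for the measured compounds named here, compound 3 gives 54.7 nM, the highest of the three numbers measured so far, with compound 1 nearest to it and compound 2 furthest from it.

Compound 4, `O=C(c1ccco1)N1CCN(c2ccc(=O)n(CCCCCCCN3CCN(c4ccccc4Cl)CC3)n2)CC1`, has not yet been measured. It stands to compound 3 as compound 2 stands to compound 1: the change is chloro in place of methoxy on an aromatic carbon, and the place described for it matches the place described for the change from compound 1 to compound 2 word for word, so it is the same change made on the second core. Going by the values given here, the only guide to its effect is the one measured instance of it, the step from compound 1 to compound 2. On that basis a step of similar size is expected, a 3.0-fold lower number from compound 3 to compound 4 (0.48 log units; beyond the scatter), resting on the step of a 3.0-fold lower number from compound 1 to compound 2 (0.48 log units; beyond the scatter) within the first core. The expected value for compound 4 in this assay is therefore 18 nM, with the likely range running from 8 nM to 40 nM.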

Compound 4, inhibition constant: 5.6 nM
For compound 4 the middle estimate is 3.2-fold (0.51 log units) above the measured one; measured number below the stated range.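

In this assay, the change from 2-methoxyphenyl to 2-chlorophenyl on the second core gives a 9.8-fold lower number from compound 3 to compound 4 (0.99 log units; beyond the scatter), so the direction of the step carried over from the core of compound 1 to the core of compound 3, but its size did not: the same change on two cores in this assay, a 3.0-fold lower number (0.48 log units; beyond the scatter) from compound 1 to compound 2 and a 9.8-fold lower number (0.99 log units; beyond the scatter) from compound 3 to compound 4, 3.2-fold (0.51 log units) apart, beyond the scatter of two such steps

This shows that, in these two pairs, the same exchange lowered the number on both cores, yet a step measured on one core was a sound guide only to the direction of the step on the other, not to how large it would be. For the compounds shown here, it does not show why the two steps differ in size, and with only one pair on each core it cannot establish that either step is typical of its core or predict the step on any further core.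

The compounds shown leave open how other groups on the same aromatic carbon, such as fluoro or methyl, would compare with methoxy and chloro on these two cores. They also leave open whether the gap between the two steps would persist with a shorter or a longer chain, or at another receptor.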